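From benzyl to prop-1-yn-1-yl: what compound 3 may give

This account rests on a few compounds, and the source may have more. Where it says the series, first, only, none or still open, it means among the compounds named here.

Compound 1, `O=C(O)c1csc(SCCN2C(=O)OC[C@@H]2/C=C/[C@@H](O)C2(CCCCF)CCC2)n1`, gives 1080 nM in an assay on isolated protein for binding affinity to prostaglandin E2 receptor EP1 subtype (Homo sapiens); a lower number here means a stronger inhibitor, a higher number a weaker inhibitor.
Compound 2, `O=C(O)c1csc(SCCN2C(=O)OC[C@@H]2/C=C/[C@@H](O)C2(CCc3ccccc3)CCC2)n1`, gives 802 nM in this assay.

Among the two numbers measured so far, compound 2 stands at the lowest, with compound 1 as its only neighbour; the step of a 1.3-fold lower number from compound 1 to compound 2 (0.13 log units; within the scatter) shows that the two cannot be told apart with confidence. That step replaced a 2-fluoroethyl with a phenyl on the saturated chain carbon two bonds along the chain from a saturated ring carbon, and the number hardly moved.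

Compound 3, `CC#CCC1([C@H](O)/C=C/[C@H]2COC(=O)N2CCSc2nc(C(=O)O)cs2)CCC1`, is the next member of the series. Its change from compound 2 is prop-1-yn-1-yl in place of benzyl on a saturated chain carbon bound to a saturated ring carbon. Within the data shown here, the only measured step that bears on this is the one between compound 1 and compound 2, which again altered the chain on the same ring-bound carbon and came out within the scatter. On that basis no step beyond the scatter is expected for compound 3 in this assay, in either direction, and compound 3 is estimated to give 900 nM, with a likely range from 300 nM to 2700 nM. The expected step is therefore a 1.1-fold higher number from compound 2 to compound 3 (0.05 log units; within the scatter).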

Compound 3, inhibition constant: 89 nM
Compound 3: middle estimate off by 10-fold (1.00 log units), on the high side; measured number below the stated range.
By their numbers in this assay, from the lowest: compound 3; then compounds 2 and 1 (each within the scatter of the next).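

The chain on this carbon turns out not to be indifferent: in this assay, prop-1-yn-1-yl in place of benzyl gives a 9.0-fold lower number from compound 2 to compound 3 (0.95 log units; beyond the scatter), and the same group in place of 3-fluoropropyl gives a 12-fold lower number from compound 1 to compound 3 (1.08 log units; beyond the scatter). The earlier step, a 1.3-fold lower number from compound 1 to compound 2 (0.13 log units; within the scatter), lay within the scatter and suggested that this place tolerated quite different chains with little effect, whereas compound 3 now stands clearly apart from both earlier compounds, and it alone among the three carries a triple bond outside aromatic rings. No supporting measurement is available to explain why this change matters so much.

The compounds shown do not separate the triple bond from the other things that change with it, since the step from compound 2 to compound 3 also removes a six-membered aromatic ring and shortens the group from 7 heavy atoms to 3. Going by these compounds, whether a plain propyl chain, a prop-1-en-1-yl group or a longer alkyne such as pent-2-yn-1-yl on the same carbon would hold the lower number remains open.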